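Bromo for methyl on the fused ring of compound 3

The source may hold more compounds than are shown below. What is called first, only, known or untested is meant among the compounds shown, and "the series" means these compounds.

Compound 3 `CCOC(=O)C1=C(C)NC(C)=C(C(=O)OCC)C1c1c(-c2cc(OC)ccc2OC)nc2sc(C)cn12` gives 4810 nM in an ADME assay on Right cardiac atrium (Cavia porcellus) (a lower number here means that less compound is needed, a higher number that more compound is needed for the effect), the highest of the three numbers: compound 2 `CCOC(=O)C1=C(C)NC(C)=C(C(=O)OCC)C1c1c(-c2ccc(Cl)cc2)nc2sc(Cl)cn12` gives 1730 nM and compound 1 `CCOC(=O)C1=C(C)NC(C)=C(C(=O)OCC)C1c1c(-c2ccc(F)cc2)nc2sc(C)cn12` gives 23 nM. Going by the values given here, the only single-place step, a 210-fold higher number from compound 1 to compound 3 (2.32 log units; beyond the scatter), concerns the aryl group and not the site now changed. Compound 4 `CCOC(=O)C1=C(C)NC(C)=C(C(=O)OCC)C1c1c(-c2cc(OC)ccc2OC)nc2sc(Br)cn12` carries bromo in place of methyl on an aromatic carbon. Among the compounds with values here, no measured step bears on this change; compound 2, with chloro at the same site but also a different aryl group, is separated from compound 3 by two changes, so its number yields no step of its own. For compound 4 no step beyond the scatter is expected, a 1.2-fold higher number from compound 3 to compound 4 (0.10 log units; within the scatter). The estimate for compound 4 is 6000 nM, within 2000 nM to 18000 nM.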

Compound 4, half-maximal effective concentration: 120 nM
Compound 4: middle estimate off by 50-fold (1.70 log units), on the high side; the measured number lies below the stated range.
By their numbers in this assay, from the lowest: compound 1; then compound 4; then compound 2; then compound 3.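

The site next to the ring sulfur matters in this assay: bromo in place of methyl gives a 40-fold lower number from compound 3 to compound 4 (1.60 log units; beyond the scatter) with the 2,5-dimethoxyphenyl group unchanged. The aryl group is therefore not the only place in the series where a single change moves the number beyond the scatter. Nothing at hand gives a cause for this step.

Still open, from the compounds shown here alone, is whether bromo in place of methyl has the same effect with the 4-fluorophenyl group of compound 1. Also open, going by these compounds, is how an amine or a longer chain at this site would read.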